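Chloro on the core of compound 1

This account rests on a few compounds, and the source may have more. Where it says the series, first, only, none or still open, it means among the compounds named here.

Among the measured compounds shown here, compound 1 `O=S(=O)(c1cncc2ccccc12)n1cc(C2=CCNCC2)c2ccccc21` is one of two compounds so far measured in an assay on HEK293 cells for displacement of a labelled ligand from 5-hydroxytryptamine receptor 6 (Homo sapiens), read by scintillation counting; on this read-out higher numbers stand for weaker inhibition and lower numbers for stronger inhibition; in this assay compound 1 gives 5 nM. Compound 2 `O=S(=O)(c1cccc2ncccc12)n1cc(C2=CCNCC2)c2cc(Cl)ccc21` differs from compound 1 in more than one place, and in this assay compound 2 gives 11 nM. Compound 1 therefore stands at the lower of the two numbers, and its gap to compound 2 lies beyond the usual scatter.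

Compound 3 `O=S(=O)(c1cncc2ccccc12)n1cc(C2=CCNCC2)c2cc(Cl)ccc21` is not yet measured. It arises from compound 1 by chloro in place of hydrogen on an aromatic carbon. For the measured compounds named here, no pair of measured compounds isolates this single change: compound 2 also carries a chloro on its core, but together with a second difference elsewhere, so its number cannot be read as the effect of the chloro alone.

The step from compound 1 to compound 3 is expected to be small, a 1.4-fold higher number from compound 1 to compound 3 (0.15 log units; within the scatter), if anything toward a somewhat higher number, and not clearly beyond the scatter. In this assay compound 3 is expected to give about 7 nM, within a range from 2.5 nM to 20 nM.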

Compound 3, inhibition constant: 18 nM
Estimate against measurement, compound 3: 2.6-fold (0.41 log units) below, and the stated range covers the measured number.
By their numbers in this assay, from the lowest: compound 1; then compounds 2 and 3 (each within the scatter of the next).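

Among the compounds shown here, compound 3 gives the first reading of chloro alone on this aromatic carbon, meta to a fused ring and para to a fused ring: in this assay, the single change gives a 3.6-fold higher number from compound 1 to compound 3 (0.56 log units; beyond the scatter). The chloro on compound 2 came with a second difference, so this step is what separates the change from that difference, and it shows that on the core of compound 1 the replacement of hydrogen by chloro moves the number beyond the scatter, though only modestly. No measurement at hand accounts for the size or direction of this step.

Still open, from the compounds shown here alone, is whether this step belongs to chloro itself or to any substituent on this carbon, a question that fluoro, methyl, methoxy or a nitrile at the same place would address. Also open is whether the step carries over to the sulfonyl group of compound 2, since the compounds shown hold that group only together with the chloro, and a single position with a single substituent gives no trend across the series.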